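Swapping pyrrolidin-1-yl for 4-methyl-1H-imidazol-1-yl in compound 3

A few compounds are considered here, and "the series" means these few. Any claim that something is new, unique, unknown or untested is made for them only; others in the source may bear on it.

In an ADME assay on BaF3 cells (Mus musculus) for antiproliferative activity, read by CCK-8 assay, with a stated time of 72 h (on this read-out higher numbers stand for weaker inhibition of growth and lower numbers for stronger inhibition of growth), compound 1 `O=C(CCSc1ccc2c(/C=C/c3ccccn3)n[nH]c2c1)Nc1ccc(Cl)c(C(F)(F)F)c1` gives only a limit, > 10000 nM. Compound 2 `COc1ccc(NC(=O)CCSc2ccc3c(/C=C/c4ccccn4)n[nH]c3c2)cc1C(F)(F)F` also gives only a limit, > 10000 nM. Compound 3 `O=C(CCSc1ccc2c(/C=C/c3ccccn3)n[nH]c2c1)Nc1ccc(CN2CCCC2)c(C(F)(F)F)c1` alone gives a number, 4000 nM. Two measured steps lead to it: an at least 2.5-fold lower number from compound 1 to compound 3 (0.39 log units; beyond the scatter) and an at least 2.5-fold lower number from compound 2 to compound 3 (0.39 log units; beyond the scatter). In compound 4 `Cc1cn(Cc2ccc(NC(=O)CCSc3ccc4c(/C=C/c5ccccn5)n[nH]c4c3)cc2C(F)(F)F)cn1`, 4-methyl-1H-imidazol-1-yl stands in place of pyrrolidin-1-yl on a saturated chain carbon bound to an aromatic carbon (4-methyl-1H-imidazol-1-yl in place of pyrrolidin-1-yl on a saturated chain carbon bound to an aromatic carbon). Neither measured step changes that ring, and both bear on the change only indirectly. The expected change is a 1.3-fold higher number from compound 3 to compound 4 (0.10 log units; within the scatter), with no step beyond the scatter anticipated. Going by these compounds, the upper side stays open, given (the limit of > 10000 nM in this assay, at which 2 of the 3 values shown sit). For compound 4 the estimated value is 5000 nM, with an expected range of 2000 nM to 10000 nM.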

Compound 4, concentration for 50% growth inhibition: 1990 nM
For compound 4 the middle estimate is 2.5-fold (0.40 log units) above the measured one; the measured number lies below the stated range.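

In this assay, the result shows that this saturated chain carbon accepts an aromatic ring as well as a non-aromatic one, with a 2.0-fold lower number from compound 3 to compound 4 (0.30 log units; within the scatter). The advantage over methoxy and chloro is therefore not confined to (pyrrolidin-1-yl)methyl, as an at least 5.0-fold lower number from compound 2 to compound 4 (0.70 log units; beyond the scatter) and an at least 5.0-fold lower number from compound 1 to compound 4 (0.70 log units; beyond the scatter) show. Both of these steps start from a limit of the assay, not a number: the limit of > 10000 nM in this assay, at which 2 of the 4 values shown sit.

The compounds shown leave open whether morpholin-4-yl or dimethylamino on the same carbon would keep this level. They also leave open whether unsubstituted 1H-imidazol-1-yl would do the same as 4-methyl-1H-imidazol-1-yl.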